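The source may hold more compounds than are shown below. What is called first, only, known or untested is meant among the compounds shown, and "the series" means these compounds.

Working notes on the series. In a functional assay on G-361 cells (Homo sapiens) for cytotoxicity (on this read-out lower numbers stand for stronger inhibition and higher numbers for weaker inhibition), compound 1 `CC(C)n1cnc2c(NCc3ccc(O)cc3)nc(NCCCO)nc21` gives 23000 nM and compound 2 `CC(C)n1cnc2c(NCc3cccc(O)c3)nc(NCCCO)nc21` gives 26000 nM. Within the data shown here, these two values lie within the scatter of each other, so compound 2 stands level with the only other measured compound. Compound 3 `CC(C)C(CO)Nc1nc(NCc2cccc(O)c2)c2ncn(C(C)C)c2n1` has 1-(hydroxymethyl)-2-methylpropyl in place of 3-hydroxypropyl on a nitrogen on an aromatic ring. Among the measured compounds shown here, the one measured step, a 1.1-fold higher number from compound 1 to compound 2 (0.05 log units; within the scatter), moves the hydroxyl on the phenyl group and stays within the scatter. For the measured compounds named here, it does not touch the changed chain, so it offers no direct precedent. Going by the values given here, with no measured step at this place, only a modest shift towards a lower number in this assay is expected, and that direction is tentative. The expected size of the change is a 2.2-fold lower number from compound 2 to compound 3 (0.34 log units; beyond the scatter). For compound 3 the estimated value is 12000 nM, with an expected range of 4000 nM to 35000 nM.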

Compound 3, half-maximal inhibitory concentration: 12000 nM
Beside the measured number, compound 3's estimate shows no gap at the digits printed; the measured number falls inside the stated range.
By their numbers in this assay, from the lowest: compounds 3, 1 and 2 (each within the scatter of the next, the first and the last beyond it).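

The chain on the nitrogen on an aromatic ring responds in this assay where the hydroxyl move on the phenyl group did not: 1-(hydroxymethyl)-2-methylpropyl in place of 3-hydroxypropyl gives (a 2.2-fold lower number from compound 2 to compound 3 (0.34 log units; beyond the scatter)), the only step shown that lies beyond the scatter. The step is modest, but it shows that this chain can take a larger, branched group, with 6 heavy atoms in place of 4, without any loss on this read-out. Nothing available explains the shift.

The compounds shown do not separate the effect of the branching from that of the added carbons or the changed hydroxyl placement on the chain. They also leave open whether the chain hydroxyl matters at all, which an amine in its place or a plain 3-methylbutyl chain would address.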